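The source may report more compounds than this note shows. Statements on the series, on what has been measured and on what is new or still open speak of the compounds shown alone.

Measured so far:
compound 1 `O=c1[nH]cc(S(=O)(=O)Nc2cccc(-c3cn(-c4ccc(Cl)cc4)nn3)c2)c(=O)[nH]1`: 2160 nM
compound 2 `Cc1ccc(-n2cc(-c3ccc(NS(=O)(=O)c4c[nH]c(=O)[nH]c4=O)cc3)nn2)cc1`: 8350 nM

Both values come from a functional assay on SGC-7901 cells (Homo sapiens) for antiproliferative activity, read by MTT assay, with a stated time of 24 h; a lower number here means a stronger inhibitor, a higher number a weaker inhibitor. Compound 2 gives the higher of the two numbers, and the gap to compound 1 lies beyond the usual scatter; the two structures differ in more than one place, so no single change can be read from that pair. Compound 3 `O=c1[nH]cc(S(=O)(=O)Nc2ccc(-c3cn(-c4ccccc4Cl)nn3)cc2)c(=O)[nH]1` differs from compound 2 in one place: 2-chlorophenyl in place of 4-methylphenyl on an aromatic nitrogen. For the measured compounds named here, no pair of measured compounds isolates this change, so the size of the step cannot be taken from the data. Compound 1, which also carries a chlorophenyl group on the same ring nitrogen, gives a lower number than compound 2 in this assay, but it differs elsewhere as well. A modest step towards a lower number is expected for compound 3, a 1.7-fold lower number from compound 2 to compound 3 (0.22 log units; within the scatter), possibly no larger than the scatter. Compound 3 is estimated at 5000 nM in this assay, within 1500 nM to 16000 nM.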

Compound 3, half-maximal inhibitory concentration: 2680 nM
Compound 3: the middle estimate sits 1.9-fold (0.27 log units) above what was measured; the measured number falls inside the stated range.
By their numbers in this assay, from the lowest: compounds 1 and 3 (each within the scatter of the next); then compound 2.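

In this assay the group on the aromatic nitrogen of the five-membered ring now has a step of its own: 2-chlorophenyl in place of 4-methylphenyl gives a 3.1-fold lower number from compound 2 to compound 3 (0.49 log units; beyond the scatter) and so a modest effect at this position, which the earlier pair could not isolate. The step comes with no change in heavy-atom count or hydrogen-bond donor and acceptor counts, as both groups hold the same totals on these measures. Nothing measured here accounts for the step.

The change swaps methyl for chlorine and also moves the substituent on the phenyl ring, and the compounds shown do not separate these two changes. Going by these compounds, whether an unsubstituted phenyl, a methoxy group or an amine on that ring would shift the number further also remains open.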